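A few compounds are considered here, and "the series" means these few. Any claim that something is new, unique, unknown or untested is made for them only; others in the source may bear on it.

Series notes. For the measured compounds named here, compound 1 `CCN(Cc1ccncc1)C(=S)SCc1ccc(C(=O)Nc2ccccc2N)cc1` stands highest of the three compounds measured so far: in a functional assay on MGC-803 cells (Homo sapiens) for antiproliferative activity, read by CCK-8 assay, with a stated time of 72 h, tested at 2 uM (on this read-out higher numbers stand for a stronger effect at the one concentration tested and lower numbers for a weaker effect), compound 1 gives 71.6%. Compound 3 `Nc1ccccc1NC(=O)c1ccc(CSC(=S)N2CCN(c3ccccc3F)CC2)cc1` comes nearest, yet in this assay compound 3 gives only 33.7%, a gap beyond the scatter. Furthest off is compound 2 `Nc1ccccc1NC(=O)c1ccc(CSC(=S)N2CCc3ccc([N+](=O)[O-])cc32)cc1`, for which this assay gives 30.6%, again beyond the scatter.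

Compound 4 `Nc1ccccc1NC(=O)c1ccc(CSC(=S)N2CCc3cc(Cl)ccc32)cc1` has not yet been measured. It differs from compound 1 in one place: 5-chloro-2,3-dihydro-1H-indol-1-yl in place of ethyl((pyridin-4-yl)methyl)amino on a thiocarbonyl carbon. The step from compound 1 to compound 4 is expected to run downward beyond the scatter, a number 31.6 percentage points lower from compound 1 to compound 4 (beyond the scatter), because compound 2 gives 30.6%. For compound 4 the read-out in this assay is therefore estimated at 40%, with a range from 25% to 60%.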

Compound 4, a percentage reported as inhibition, at one concentration (the size of the read-out at that concentration, not a potency): 57.7%
The estimate for compound 4 lay 17.7 percentage points below the measured number, and the stated range covers the measured number.
By their numbers in this assay, from the lowest: compounds 2 and 3 (each within the scatter of the next); then compound 4; then compound 1.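

On a thiocarbonyl carbon, 5-chloro-2,3-dihydro-1H-indol-1-yl in place of ethyl((pyridin-4-yl)methyl)amino gives, in this assay, a number 13.9 percentage points lower from compound 1 to compound 4 (beyond the scatter). The position therefore tolerates losing the pyridine ring and its counted hydrogen-bond acceptor with only a modest drop at this one concentration. Nothing measured here bears on the reason for this step.

Still open, from the compounds shown here alone, is how much of the step belongs to the ethyl group and how much to the pyridine ring, since both leave together. A morpholine ring or a simple diethylamino group on this carbon would test the same position further.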